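Working notes: from compound 3 to compound 4

This account rests on a few compounds, and the source may have more. Where it says the series, first, only, none or still open, it means among the compounds named here.

In an ADME assay on MT4 cells (Homo sapiens) for cytotoxicity, read by MTT assay (on this read-out lower numbers stand for higher toxicity in this test and higher numbers for lower toxicity in this test), compound 1 (`O=C(CSc1nncnc1-c1cccc2ccccc12)Nc1ccccc1[N+](=O)[O-]`) gives 142000 nM, compound 2 (`O=C(CSc1nncnc1-c1cccc2ccccc12)Nc1ccccc1Cl`) gives 63000 nM and compound 3 (`Cc1ccc(NC(=O)CSc2nncnc2-c2cccc3ccccc23)c([N+](=O)[O-])c1`) gives 147000 nM. Compound 3 shares the high end of these numbers with compound 1, and compound 2 sits under both.

The next member, compound 4 (`O=C(CSc1nncnc1-c1cccc2ccccc12)Nc1ccccc1F`), carries 2-fluorophenyl in place of 4-methyl-2-nitrophenyl on an amide-type nitrogen.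

For the measured compounds named here, two measured steps bear on this change. The methyl step, a 1.0-fold higher number from compound 1 to compound 3 (0.02 log units; within the scatter), lies within the scatter, so losing the methyl is expected to matter little. Going by the values given here, the chloro in place of nitro step, a 2.3-fold lower number from compound 1 to compound 2 (0.35 log units; beyond the scatter), is modest and is the closest precedent, and a 2.3-fold higher number from compound 2 to compound 3 (0.37 log units; beyond the scatter) shows a gap of similar size. Among the compounds with values here, no measured compound carries 2-fluorophenyl, so the precedent is indirect. A modest move to a lower number is therefore expected in this assay.

The expected change is a 2.1-fold lower number from compound 3 to compound 4 (0.32 log units; beyond the scatter). Compound 4 is estimated at 70000 nM, with an expected range of 35000 nM to 140000 nM.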

Compound 4, half-maximal cytotoxic concentration: 65000 nM
Compound 4: the middle estimate sits 1.1-fold (0.03 log units) above what was measured, within the range that was stated.
By their numbers in this assay, from the lowest: compounds 2 and 4 (each within the scatter of the next); then compounds 1 and 3 (each within the scatter of the next).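

In this assay fluoro in place of chloro on an aromatic carbon gives a 1.0-fold higher number from compound 2 to compound 4 (0.01 log units; within the scatter) and so does not separate the two halogens at this position. Fluoro in place of nitro gives a 2.2-fold lower number from compound 1 to compound 4 (0.34 log units; beyond the scatter) and the full exchange of groups on the amide-type nitrogen gives a 2.3-fold lower number from compound 3 to compound 4 (0.35 log units; beyond the scatter) and both steps are modest, so compounds 2 and 4 stand apart from compounds 1 and 3, with none of the four going against this split. Nothing measured here explains the split.

Going by these compounds, whether a low number follows from a halogen or from the absence of nitro stays open, and an amine or a carboxylic acid on the same aromatic carbon would test this. On these data alone, how the methyl step behaves with fluoro on the ring also remains unknown.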